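The source may hold more compounds than are shown below. What is called first, only, known or untested is meant among the compounds shown, and "the series" means these compounds.

Three measured compounds share one core and differ in a single group. Compound 1 `O=[N+]([O-])c1ccc(Nc2nc3c(N4CCCC4)ncnc3s2)cc1` carries a nitro group, compound 2 `Clc1ccc(Nc2nc3c(N4CCCC4)ncnc3s2)cc1` a chloro group, and compound 3 `Cc1ccc(Nc2nc3c(N4CCCC4)ncnc3s2)cc1` a methyl group. In a functional assay on CHO-K1 cells for antagonist activity at adenosine receptor A2b (Homo sapiens), read by 33P incorporation, with a stated time of 20 min, in the presence of a further agent that is not named here (a higher number here means a weaker inhibitor, a lower number a stronger inhibitor), compound 1 gives > 10000 nM, which is a limit of the assay and not a number. In this assay compound 2 likewise gives only a limit, > 10000 nM. In this assay compound 3 also gives a limit, > 10000 nM. All three therefore sit at the limit of > 10000 nM in this assay, at which 3 of the 3 values shown sit, and the measured steps cannot be read: a step that the two limits leave unreadable from compound 1 to compound 2, a step that the two limits leave unreadable from compound 1 to compound 3, a step that the two limits leave unreadable from compound 2 to compound 3. Compound 2 thus stands where the other two stand, at a limit rather than at a value.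

Compound 4 `CN(C)c1ncnc2sc(Nc3ccc(Cl)cc3)nc12` differs from compound 2 in one place: dimethylamino in place of pyrrolidin-1-yl on an aromatic carbon. Among the compounds with values here, no measured step bears on this change; the only measured steps concern the nitro, chloro and methyl groups, and all are unreadable. The expectation for compound 4 in this assay is therefore again a limit, estimated at 15000 nM with a range from 3000 nM to 60000 nM. The change is expected to give a step that the limit leaves unreadable from compound 2 to compound 4, not beyond the scatter.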

Compound 4, inhibition constant: > 10000 nM
Compound 4: a limit, no number; the forecaster's own chance of this, stated with the estimate: 80%; the middle value does not contradict the limit.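

In this assay compound 4 gives > 10000 nM as a limit of the assay and not a number. Within the data shown here, no step between compound 2 and compound 4 can be read, and the series stays at one limit: the limit of > 10000 nM in this assay, at which 4 of the 4 values shown sit.
The compounds shown leave open which change to the shared core, if any, would give a measurable value in this assay at all.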